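This account rests on a few compounds, and the source may have more. Where it says the series, first, only, none or still open, it means among the compounds named here.

Measured in a functional assay on HCT-116 cells (Homo sapiens) for cytotoxicity, read by MTT assay, with a stated time of 72 h; a higher number here means a weaker inhibitor, a lower number a stronger inhibitor:
- Compound 1 (`COC(=O)C(COC(=O)/C=C/c1ccc(OC)c(OC)c1)c1ccccc1`): > 0.01 ug/mL
- Compound 2 (`CCOC(=O)C(COC(=O)c1ccccc1OC(C)=O)c1ccc(F)cc1`): > 0.01 ug/mL
- Compound 3 (`CCOC(=O)C(COC(=O)/C=C/c1ccc(OC)c(OC)c1)c1ccc(F)cc1`): > 0.01 ug/mL

Each entry is a limit of the assay and not a number. Compound 3 gives > 0.01 ug/mL, so its position can only be stated as a limit. The series offers no numerical reference: the limit of > 0.01 ug/mL in this assay, at which 3 of the 3 values shown sit.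

Compound 4 (`CCOC(=O)C(COC(=O)/C=C/c1ccc(OC)c(OC)c1)c1ccc(C(F)(F)F)cc1`) has trifluoromethyl in place of fluoro on an aromatic carbon, para to a large group, which takes 4-fluorophenyl to 4-(trifluoromethyl)phenyl: trifluoromethyl in place of fluoro on an aromatic carbon. Among the measured compounds shown here, no measured pair isolates this change, so its size cannot be read from the data. In this assay, no step beyond the scatter is expected in either direction. This expectation rests on compound 3 at > 0.01 ug/mL, again only a limit. The estimated change is a step that the limit leaves unreadable from compound 3 to compound 4. For compound 4 the estimated value is 0.015 ug/mL, with an expected range from 0.005 ug/mL to 0.1 ug/mL.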

Compound 4, half-maximal inhibitory concentration: > 0.01 ug/mL
Compound 4 ended at the assay's limit; the forecaster's own chance of this, stated with the estimate: 75%; the middle value does not contradict the limit.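

No step can be read between compound 3 and compound 4, as both entries are limits of the assay and not numbers: the limit of > 0.01 ug/mL in this assay, at which 4 of the 4 values shown sit.

The compounds shown leave open whether trifluoromethyl in place of fluoro on an aromatic carbon changes the read-out at all, and by how much.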